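A few compounds are considered here, and "the series" means these few. Any claim that something is new, unique, unknown or untested is made for them only; others in the source may bear on it.

In an assay on HEK293 cells for agonist activity at Toll-like receptor 8 (Homo sapiens), read by a luciferase reporter, with a stated time of 6 h (a lower number here means that less compound is needed, a higher number that more compound is needed for the effect), compound 1 `CCCCNc1nc(N)nc2c1CN(Cc1c(Cl)cccc1Cl)CC2` gives 0.14 uM, and compound 2 `CCCCNc1nc(N)nc2c1CN(Cc1cccnc1)CC2` gives 0.13 uM. For the measured compounds named here, the one measured step, a 1.1-fold lower number from compound 1 to compound 2 (0.03 log units; within the scatter), swapped only the aromatic ring on the ring nitrogen of the shared core, so compound 2 stands level with compound 1 on these two numbers. Compound 3 `CCCCNc1nc(N)nc2c1CN(C(=O)c1cnccn1)CC2` differs from compound 2 by (pyrazin-2-yl)carbonyl in place of (pyridin-3-yl)methyl on an amine nitrogen in a ring. Going by the values given here, no measured step covers a carbonyl at that place, so the expectation rests on a single, flat step and is uncertain. The expected step is a 3.1-fold higher number from compound 2 to compound 3 (0.49 log units; beyond the scatter). Compound 3 is estimated at 0.4 uM, ranging from 0.1 uM to 2 uM.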

Compound 3, minimum effective concentration: 2.2 uM
Compound 3: the middle estimate sits 5.5-fold (0.74 log units) below what was measured, outside the stated range (above it).
By their numbers in this assay, from the lowest: compounds 2 and 1 (each within the scatter of the next); then compound 3.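

The amine nitrogen in the ring of the shared core is sensitive after all: the flat step from compound 1 to compound 2 gave no sign of this, yet the change to (pyrazin-2-yl)carbonyl gives a 17-fold higher number from compound 2 to compound 3 (1.23 log units; beyond the scatter) in this assay. An aromatic ring can therefore be exchanged here without a visible shift, while this larger change cannot. No evidence available here accounts for this step.

The carbonyl and the pyrazine ring enter together, so the compounds shown leave open which of them carries the step. A (pyrazin-2-yl)methyl or (pyridin-3-yl)carbonyl group at this nitrogen would separate the two.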